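The compounds below may be only part of what the source reports. "The series", "measured", "known", "first", "only" and "open" are said of these compounds alone.

Compound 1 `C=C[C@@H]1OC(c2ccc(C)cc2)=N[C@H]1CO` was tested in an assay on isolated protein for inhibition of matrix metalloproteinase-9 (Homo sapiens) (a lower number here means a stronger inhibitor, a higher number a weaker inhibitor), and gave 68000 nM. Among the three measured compounds it holds the second highest number. Compound 2 `C=C[C@@H]1OC(c2ccc(-c3ccccc3)cc2)=N[C@H]1SC(C)=O` gives 81000 nM in this assay, a number that lies within the scatter of the value of compound 1. Compound 3 `C=C[C@@H]1OC(/C=C\C=C\c2ccccc2)=N[C@H]1CO` gives 8000 nM in this assay, a markedly lower number than that of compound 1. Compound 4 `C=C[C@@H]1OC(c2ccc(Br)cc2)=N[C@H]1CO` has not yet been measured; it differs from compound 1 by bromo in place of methyl on an aromatic carbon. Among the compounds with values here, no pair of measured compounds isolates this change, so its effect on the inhibition constant remains open. The step that is expected is a 1.2-fold lower number from compound 1 to compound 4 (0.09 log units; within the scatter), which would stay within the scatter. Compound 4 is estimated at 55000 nM in this assay, with a range from 20000 nM to 150000 nM.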

Compound 4, inhibition constant: 9000 nM
For compound 4 the middle estimate is 6.1-fold (0.79 log units) above the measured one, outside the stated range (below it).
By their numbers in this assay, from the lowest: compounds 3 and 4 (each within the scatter of the next); then compounds 1 and 2 (each within the scatter of the next).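

Bromo in place of methyl on an aromatic carbon, para to a group of 9 heavy atoms, gives a 7.6-fold lower number from compound 1 to compound 4 (0.88 log units; beyond the scatter) in this assay, so this position responds to the group it carries. The exchange leaves the heavy-atom count unchanged and adds no hydrogen-bond donor or acceptor, so these counts do not separate the two groups. No measurement at hand accounts for the step. On these data alone, whether chloro, methoxy or an amine at this place would give a similar number remains open. So does whether the same exchange would have a similar effect on another core.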